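This account rests on a few compounds, and the source may have more. Where it says the series, first, only, none or still open, it means among the compounds named here.

In a functional assay on HeLa cells (Homo sapiens) for antiproliferative activity, read by MTT assay, with a stated time of 72 h (a lower number here means a stronger inhibitor, a higher number a weaker inhibitor), compound 1 `CCCn1ccnc1-c1cc(OC)c(OC)c(OC)c1` reads > 100000 nM, which is a limit of the assay and not a number. Going by the values given here, compound 2 `COc1cc(-c2nccn2-c2ccc(C)cc2)cc(OC)c1OC` gives 700 nM, the only true number so far. Among the compounds with values here, the single measured step, an at least 140-fold lower number from compound 1 to compound 2 (2.15 log units; beyond the scatter), is large, but it replaces propyl on an aromatic nitrogen and does not size a smaller edit on the 4-methylphenyl group. Compound 3 `COc1ccc(-n2ccnc2-c2cc(OC)c(OC)c(OC)c2)cc1` carries methoxy in place of methyl on an aromatic carbon, para to a large group: methoxy in place of methyl on an aromatic carbon. No change beyond the scatter is expected in this assay, and no firm direction. The expected step is a 1.4-fold lower number from compound 2 to compound 3 (0.15 log units; within the scatter). For compound 3 the estimate is 500 nM, with an expected range of 100 nM to 3000 nM.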

Compound 3, half-maximal inhibitory concentration: 1200 nM
Compound 3: the middle estimate sits 2.4-fold (0.38 log units) below what was measured, and the stated range covers the measured number.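

In this assay, the change from 4-methylphenyl to 4-methoxyphenyl gives a 1.7-fold higher number from compound 2 to compound 3 (0.23 log units; within the scatter), so methyl and methoxy cannot be told apart at this position. The large gain over propyl on the aromatic nitrogen is not confined to 4-methylphenyl, since 4-methoxyphenyl also gives an at least 83-fold lower number from compound 1 to compound 3 (1.92 log units; beyond the scatter). The size of that step stays open-ended, as compound 1 reads at a limit and not a number: the limit of > 100000 nM in this assay, at which 1 of the 3 values shown sits.

From the compounds shown here alone, whether an amine or a hydroxyl at this position would also leave the number unchanged remains open. So does how a benzyl group or a longer chain on the nitrogen would read.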